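The source may hold more compounds than are shown below. What is called first, only, known or untested is meant among the compounds shown, and "the series" means these compounds.

Values in a physicochemical assay for solubility; a higher number here means a more soluble compound, a lower number a less soluble compound:
- compound 1 `O=C(Nc1ccc([N+](=O)[O-])cc1)c1cc(Cl)ccc1O`: 6.4 ug/mL
- compound 2 `COc1ccc(NC(=O)c2cc(Cl)ccc2O)cc1`: 2.8 ug/mL

Compound 2 holds the lower of the two numbers, at 2.8 ug/mL. Compound 3 `Cc1ccc(NC(=O)c2cc(Cl)ccc2O)cc1` has methyl in place of methoxy on an aromatic carbon. Going by the values given here, only one measured step bears on this place, a 2.3-fold lower number from compound 1 to compound 2 (0.36 log units; beyond the scatter), and it is modest and involves no methyl. In this assay no step beyond the scatter is therefore expected, and the estimated step is a 1.1-fold lower number from compound 2 to compound 3 (0.05 log units; within the scatter). The estimate for compound 3 is 2.5 ug/mL, with an expected range of 1.1 ug/mL to 5.5 ug/mL.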

Compound 3, solubility: < 1 ug/mL
Compound 3 ended at the assay's limit; the forecaster's own chance of this, stated with the estimate: 10%; middle value at least 2.5-fold (0.39 log units) from the limit.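

In this assay this position, para to a large group, also responds to methyl in place of methoxy, which gives an at least 2.8-fold lower number from compound 2 to compound 3 (0.44 log units; beyond the scatter). Methyl in place of nitro gives an at least 6.4-fold lower number from compound 1 to compound 3 (0.80 log units; beyond the scatter), so nitro, methoxy and methyl now fall in one order here, with each step beyond the scatter. The value of compound 3 is a limit of the assay and not a number: the limit of < 1 ug/mL in this assay, at which 1 of the 3 values shown sits.

As far as these compounds go, how far compound 3 lies past that limit stays open. Also open, from the compounds shown here alone, is where an amine or a carboxylic acid at this position would fall relative to compound 1.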